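The compounds below may be only part of what the source reports. "The series", "measured", "known", "first", "only" and "open" are said of these compounds alone.

Working notes on the series. For the measured compounds named here, compound 2 `Cc1n[nH]c(-c2ccccc2NCC2=NCCN2)n1` stands at the high end of the two numbers so far in an in vitro functional assay on cells (Fibroblast) for agonist activity at Alpha-1A adrenergic receptor (Homo sapiens); on this read-out lower numbers stand for an effect already at smaller amounts and higher numbers for an effect only at larger amounts of compound: compound 2 gives 794 nM. Going by the values given here, its nearest neighbour is compound 1 `Cn1ncnc1-c1ccccc1NCC1=NCCN1`, which in this assay gives 2 nM; the single step of a 400-fold higher number from compound 1 to compound 2 (2.60 log units; beyond the scatter) is large and beyond the scatter.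

Compound 3 `Cn1ccc(-c2ccccc2NCC2=NCCN2)n1` is not yet measured. The change is 1-methyl-1H-pyrazol-3-yl in place of 3-methyl-1H-1,2,4-triazol-5-yl on an aromatic carbon. Among the compounds with values here, the only step that bears on it is a 400-fold higher number from compound 1 to compound 2 (2.60 log units; beyond the scatter), which shows that, on this carbon, the group with a hydrogen-bond donor sits far weaker than the one carrying a methyl on ring nitrogen. Within the data shown here, compound 3 again has no hydrogen-bond donor on its five-membered ring and again carries a methyl on ring nitrogen, but the ring has 2 hetero atoms rather than 3, and there is no measured pair for that exchange. A step back toward compound 1 is therefore expected, though not necessarily all the way.

Compound 3 is estimated at 60 nM in this assay, in a range of 8 nM to 500 nM. The estimated step is a 13-fold lower number from compound 2 to compound 3 (1.12 log units; beyond the scatter), expected to be beyond the scatter.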

Compound 3, half-maximal effective concentration: 3.16 nM
Estimate against measurement, compound 3: 19-fold (1.28 log units) above; the measured number lies below the stated range.
By their numbers in this assay, from the lowest: compounds 1 and 3 (each within the scatter of the next); then compound 2.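

In this assay, the step of a 250-fold lower number from compound 2 to compound 3 (2.40 log units; beyond the scatter) is large, and with it compound 2, the only one of the three with a hydrogen-bond donor on the five-membered ring, stands apart from both compounds that carry a methyl on ring nitrogen; no compound shown goes against this, but three compounds are a narrow base. The step of a 1.6-fold higher number from compound 1 to compound 3 (0.20 log units; within the scatter) adds what the earlier pair could not show: on this aromatic carbon, 1-methyl-1H-pyrazol-3-yl, with 2 hetero atoms in its ring, and 1-methyl-1H-1,2,4-triazol-5-yl, with 3, cannot be told apart on this read-out. No measurement among the data gives a reason for either step.

The hydrogen-bond donor and the place of the methyl change together in both large steps, so the compounds shown cannot separate the two, and a pyrazole with its methyl on carbon and a hydrogen on ring nitrogen would be the missing comparison. From the compounds shown here alone, how much room the ring nitrogen substituent allows also stays open, since only methyl appears there and an ethyl or a longer chain, or a primary amine on the five-membered ring, lies outside these compounds.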